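The source may hold more compounds than are shown below. What is called first, only, known or untested is meant among the compounds shown, and "the series" means these compounds.

In an ADME assay on L6 cells (Rattus norvegicus) for cytotoxicity, read by resazurin assay, with a stated time of 72 h (a higher number here means a weaker inhibitor, a lower number a stronger inhibitor), three compounds have been measured so far. Compound 1 (`OC(c1ccc(Cl)cc1)(c1cccnc1)c1ccccc1Cl`) gives 61300 nM in this test, compound 2 (`Cc1ccc(C(O)(c2ccc(Cl)cc2)c2cccnc2)cc1`) gives 61000 nM and compound 3 (`OC(c1ccc(Cl)cc1)(c1ccc(Br)cc1)c1cccnc1`) gives 57000 nM on the same scale. Compound 1 therefore stands level with the other two, as all three numbers lie within the scatter of one another.

Compound 4 (`OC(c1ccc(Cl)cc1)(c1ccncn1)c1ccccc1Cl`) keeps the rest of compound 1 but carries pyrimidin-4-yl in place of pyridin-3-yl on a saturated chain carbon bound to two aromatic carbons and an oxygen on a saturated carbon.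

Among the measured compounds shown here, no measured step touches that ring, so the evidence is only indirect. The three known steps all change a different part of the molecule: there is a 1.0-fold lower number from compound 1 to compound 2 (0.00 log units; within the scatter) and also a 1.1-fold lower number from compound 1 to compound 3 (0.03 log units; within the scatter) as well as a 1.1-fold lower number from compound 2 to compound 3 (0.03 log units; within the scatter) and each of them stays within the scatter. They show a flat picture among these three compounds, yet they say nothing direct about the new ring, which keeps the expectation loose.

In this assay the estimated change is a 1.0-fold lower number from compound 1 to compound 4 (0.01 log units; within the scatter) and so no shift beyond the scatter is expected in either direction. For compound 4 the estimated value is 60000 nM with an expected range from 25000 nM to 120000 nM as the likely span.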

Compound 4, half-maximal inhibitory concentration: > 100000 nM
Compound 4: only a limit was reported (the forecaster's own chance of this, stated with the estimate: 15%); middle value at least 1.6-fold (0.22 log units) from the limit.
By their numbers in this assay, from the lowest: compounds 3, 2 and 1 (each within the scatter of the next). At a limit, above all of these: compound 4.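

In this assay compound 4 reads > 100000 nM, which is a limit of the assay and not a number: the limit of > 100000 nM in this assay, at which 1 of the 4 values shown sits.

This is the only result shown for a change at this position, a saturated chain carbon bound to two aromatic carbons and an oxygen, where pyrimidin-4-yl replaces pyridin-3-yl and gives an at least 1.6-fold higher number from compound 1 to compound 4 (0.21 log units; that floor lies within the scatter). That step is a floor, so the true gap could be small or much larger, and even the floor cannot be told apart from the usual scatter of repeated measurements. The ring swap therefore may matter more than the changes to the other aryl group, which all stayed within the scatter, but the limit alone does not prove it.

The compounds shown leave open where compound 4 really lies, and whether the result belongs to pyrimidin-4-yl alone or would also hold with the 4-methylphenyl or 4-bromophenyl groups in place of 2-chlorophenyl. They also leave open how a different group at this position, such as a thiophene ring or an aminomethyl group, would read on the same scale.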